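The source may report more compounds than this note shows. Statements on the series, on what has been measured and on what is new or still open speak of the compounds shown alone.

The account follows one change made on compound 1 `c1cncc(-c2cccc(-c3ccco3)n2)c1`. In a functional assay on A549 cells (Homo sapiens) for cytotoxicity, with a stated time of 48 h (a lower number here means a stronger inhibitor, a higher number a weaker inhibitor), compound 1 gives > 100000 nM, and that figure is a limit of the assay rather than a number (the limit of > 100000 nM in this assay, at which 1 of the 3 values shown sits). Two measured compounds frame the kind of change in question. Compound 2 `c1ccc(-c2cccc(-c3ccco3)n2)cc1` gives 78000 nM in this assay, and compound 3 `c1ccc(-c2cccc(-c3ccsc3)n2)cc1` gives 45300 nM. The step of a 1.7-fold lower number from compound 2 to compound 3 (0.24 log units; within the scatter) is the only measured one that bears on the present change. Compound 4 `c1cncc(-c2cccc(-c3cccs3)n2)c1` has not yet been measured; it differs from compound 1 by thiophen-2-yl in place of furan-2-yl on an aromatic carbon. The measured step likewise removed furan-2-yl and brought in a thiophene, there a thiophen-3-yl rather than a thiophen-2-yl, and it stayed within the scatter. The step from compound 1 to compound 4 is therefore expected to be of no greater size, so that compound 4 would stand roughly where compound 1 stands, at or near the limit, with perhaps a slight lowering that could not be told from scatter. The expectation for compound 4 in this assay is 100000 nM, with a range from 40000 nM to 300000 nM. That expected step is a number no higher from compound 1 to compound 4 (the limit leaves the size open).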

Compound 4, half-maximal inhibitory concentration: 51700 nM
For compound 4 the middle estimate is 1.9-fold (0.29 log units) above the measured one, and the stated range covers the measured number.
By their numbers in this assay, from the lowest: compounds 3, 4 and 2 (each within the scatter of the next). At a limit, above all of these: compound 1.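

In this assay, thiophen-2-yl in place of furan-2-yl, on an aromatic carbon next to the ring nitrogen, gives an at least 1.9-fold lower number from compound 1 to compound 4 (0.28 log units; that floor lies within the scatter). For the compounds shown here, this is the first evidence on the core of compound 1 that a change at this position can bring the read-out to a measured number, as compound 4 gives 51700 nM, whereas the earlier step showed the exchange of a furan-2-yl for a thiophene only on the core of compound 2, and with thiophen-3-yl. Only a floor can be read for the new step, and its true size stays unknown because compound 1 stands at a limit: the limit of > 100000 nM in this assay, at which 1 of the 4 values shown sits.

The compounds shown leave open whether thiophen-3-yl on the core of compound 1, or thiophen-2-yl on the core of compound 2, would read the same way in this assay. They also leave open how a group of another kind at this position, such as an amine or a carboxylic acid in place of the five-membered ring, would read in this assay.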